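The compounds below may be only part of what the source reports. "The series", "measured", "known", "first", "only" and "open" are said of these compounds alone.

Measured so far in an assay on Jurkat cells for inhibition of nuclear factor NF-kappa-B p105 subunit (Homo sapiens); on this read-out lower numbers stand for stronger inhibition and higher numbers for weaker inhibition:
- compound 1 `O=C(Nc1cc(Cl)cc(Cl)c1)c1cnc(Cl)nc1C(F)(F)F`: 500 nM
- compound 2 `Cc1cc(NC(=O)c2cnc(Cl)nc2C(F)(F)F)on1`: 4000 nM
- compound 3 `O=C(Nc1cc(C(F)(F)F)cc(C(F)(F)F)c1)c1cnc(Cl)nc1C(F)(F)F`: 50 nM

Compound 3 stands lowest of the three numbers in this assay; its gap to compound 1 is beyond the scatter, and the gap to compound 2 is wider still. Compound 4 `CCCCCCCCOC(=O)c1cc(NC(=O)c2cnc(Cl)nc2C(F)(F)F)cc(C(F)(F)F)c1` differs from compound 3 by octyloxycarbonyl in place of trifluoromethyl on an aromatic carbon. No pair of measured compounds shares a change of this kind, so the direction rests on no shown step. The expectation is a modest move toward a higher number, as given by a 2.0-fold higher number from compound 3 to compound 4 (0.30 log units; within the scatter), with the direction itself uncertain. Compound 4 is therefore estimated at 100 nM in this assay, with a range from 20 nM to 600 nM.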

Compound 4, half-maximal inhibitory concentration: 1800 nM
Estimate against measurement, compound 4: 18-fold (1.26 log units) below, and the stated range ends below it.
By their numbers in this assay, from the lowest: compound 3; then compound 1; then compound 4; then compound 2.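

In this assay, among the compounds shown here, this aromatic carbon proves sensitive to the group it carries: octyloxycarbonyl in place of trifluoromethyl gives a 36-fold higher number from compound 3 to compound 4 (1.56 log units; beyond the scatter), the only step so far that changes one place. Exchanging this trifluoromethyl is therefore not neutral, and the large octyloxycarbonyl group does not retain the number of compound 3. Nothing measured bears on why the number rises. Going by these compounds, whether the step follows from the octyl chain or the carbonyl link remains open. A carboxylic acid, a methyl ester or a shorter chain at this carbon would separate the two.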